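The source may report more compounds than this note shows. Statements on the series, on what has been measured and on what is new or still open speak of the compounds shown alone.

Compound 3 `CC(C)(C)CN(Cc1ccccc1C(F)(F)F)C(=O)C1CCN(S(=O)(=O)c2ccc3[nH]ncc3c2)CC1` stands highest of the three measured compounds in a functional assay on CHO cells for positive allosteric modulation of muscarinic acetylcholine receptor M5 (Homo sapiens), read by calcium flux (on this read-out lower numbers stand for smaller maximal responses and higher numbers for larger maximal responses), giving 104%. Compound 1 `O=C(C1CCN(S(=O)(=O)c2ccc3[nH]ncc3c2)CC1)N(Cc1ccccc1C(F)(F)F)C1CCC1` gives 84% and compound 2 `O=C(C1CCN(S(=O)(=O)c2ccc3[nH]ncc3c2)CC1)N(CCO)Cc1ccccc1C(F)(F)F` gives 60%; the step of a number 20 percentage points higher from compound 1 to compound 3 (beyond the scatter) and the step of a number 44 percentage points higher from compound 2 to compound 3 (beyond the scatter) both run toward compound 3. Compound 4 `O=C(C1CCN(S(=O)(=O)c2ccc3[nH]ncc3c2)CC1)N(Cc1ccccc1C(F)(F)F)CC1CCC1` differs from compound 3 by cyclobutyl in place of tert-butyl on a saturated chain carbon bound to an amide-type nitrogen. The step that bears on it is a number 20 percentage points higher from compound 1 to compound 3 (beyond the scatter), in which a cyclobutyl directly on the amide nitrogen was exchanged for neopentyl; compound 4 carries the cyclobutyl one carbon further out. A modest move back toward compound 1 is expected, so the step of a number 12 percentage points lower from compound 3 to compound 4 (beyond the scatter) is the estimate. Compound 4 is therefore expected to give about 92%, within 78% to 106%.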

Compound 4, largest response reached (reported as percent of maximum), in percent of the reference or control that the assay uses: 103%
The estimate for compound 4 lay 11 percentage points below the measured number, within the range that was stated.
By their numbers in this assay, from the lowest: compound 2; then compound 1; then compounds 4 and 3 (each within the scatter of the next).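

At this position on a saturated chain carbon bound to an amide-type nitrogen, a ring serves as well as a branched chain in this assay: cyclobutyl and tert-butyl cannot be told apart (a number 1 percentage points lower from compound 3 to compound 4 (within the scatter)). The cyclobutyl group itself gains on the amide-type nitrogen when it enters as cyclobutylmethyl (a number 19 percentage points higher from compound 1 to compound 4 (beyond the scatter)). Cyclobutyl also holds the large margin over hydroxymethyl (a number 43 percentage points higher from compound 2 to compound 4 (beyond the scatter)). No available evidence accounts for these steps.
Still open, on these data alone, is how a cyclohexyl ring, a longer chain or an amine would read at this position.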